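Pyrrolidine in place of ethylpiperazine on the propyl chain

The source may report more compounds than this note shows. Statements on the series, on what has been measured and on what is new or still open speak of the compounds shown alone.

Measured so far in an assay on HEK293 cells for antagonist activity at Toll-like receptor 9 (Homo sapiens), read by spectrophotometry; a lower number here means a stronger inhibitor, a higher number a weaker inhibitor:
compound 1, `CN(C)Cc1ccc(CNc2nc(N3CCN(C4CCCC4)CC3)c3ncn(CCCN4CCCC4)c3n2)cc1`: 7 nM
compound 2, `CCN1CCN(CCCn2cnc3c(N4CCN(C5CCCC5)CC4)nc(NCc4ccc(F)cc4)nc32)CC1`: 250 nM
compound 3, `CCN1CCN(CCCn2cnc3c(N4CCN(C5CCCC5)CC4)nc(N)nc32)CC1`: 280 nM

Compound 2 stands second highest of the three numbers; its nearest neighbour is compound 3, and compound 1 lies far lower, beyond the scatter. Compound 4, `Fc1ccc(CNc2nc(N3CCN(C4CCCC4)CC3)c3ncn(CCCN4CCCC4)c3n2)cc1`, differs from compound 2 by pyrrolidin-1-yl in place of 4-ethylpiperazin-1-yl on a saturated chain carbon, three bonds along the chain from an aromatic nitrogen.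

Going by the values given here, the only measured step, a 1.1-fold higher number from compound 2 to compound 3 (0.05 log units; within the scatter), alters the group on the aromatic-ring nitrogen and leaves the chain untouched; it lies within the scatter. Among the compounds with values here, no measured pair isolates the chain substituent itself. Compound 1 carries the pyrrolidin-1-yl group on the chain together with a different benzyl group, and because a 1.1-fold higher number from compound 2 to compound 3 (0.05 log units; within the scatter) shows that a benzyl change alone barely moves the number, much of the wide gap between compound 1 and compound 2 is taken here to sit in the chain group.

Compound 4 is therefore expected to give a clearly lower number than compound 2, estimated at 15 nM with a range from 5 nM to 60 nM. The expected step is a 17-fold lower number from compound 2 to compound 4 (1.22 log units; beyond the scatter).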

Compound 4, half-maximal inhibitory concentration: 100 nM
The estimate for compound 4 lay 6.7-fold (0.82 log units) below the measured number; the measured number lies above the stated range.
By their numbers in this assay, from the lowest: compound 1; then compound 4; then compounds 2 and 3 (each within the scatter of the next).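

In this assay, the swap on the saturated chain carbon, now seen in a matched pair, gives a 2.5-fold lower number from compound 2 to compound 4 (0.40 log units; beyond the scatter), so pyrrolidin-1-yl in place of 4-ethylpiperazin-1-yl accounts for only a modest part of the gap to compound 1. The larger change lies on the aromatic carbon: (dimethylamino)methyl replaced by fluoro gives a 14-fold higher number from compound 1 to compound 4 (1.15 log units; beyond the scatter), a far bigger step than a 1.1-fold higher number from compound 2 to compound 3 (0.05 log units; within the scatter), so the earlier step on the aromatic-ring nitrogen gave no sign of how much this group matters. No measured evidence bears on the cause of either step.

From the compounds shown here alone, whether (dimethylamino)methyl gives a step of similar size with 4-ethylpiperazin-1-yl on the propyl chain remains open. Also open, going by these compounds, is how a morpholine on that chain, or a primary amine or carboxylic acid in place of the fluoro, would read.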